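The source may report more compounds than this note shows. Statements on the series, on what has been measured and on what is new or still open speak of the compounds shown alone.

Measured compounds:
Compound 1 `Cn1c(-c2ccccc2C(F)(F)F)nnc1C12CCC(CNS(C)(=O)=O)(CC1)CC2` — 73% in a functional assay on the whole organism (strain ICR) for inhibition, with Mus musculus as the target, with a stated time of 4 h, at a dose of 10 mg/kg by the oral route; a higher number here means more inhibition at the dose given (going by the name of the read-out), a lower number less inhibition
Compound 2 `Cn1c(-c2ccccc2C(F)(F)F)nnc1C12CCC(CCCC(C)(F)F)(CC1)CC2` — 99% in this assay
Compound 3 `CC(C)S(=O)(=O)CCC12CCC(c3nnc(-c4ccccc4C(F)(F)F)n3C)(CC1)CC2` — 88% in this assay

Compound 2 stands highest of the three in this assay; compound 3 lies nearest to it and compound 1 furthest. Compound 4 `CCOCC12CCC(c3nnc(-c4ccccc4C(F)(F)F)n3C)(CC1)CC2` differs from compound 2 in one place: a group of 3 heavy atoms (2 carbon, 1 oxygen; no ring) in place of a group of 6 heavy atoms (4 carbon, 2 fluorine; no ring), on a saturated chain carbon bound to a saturated ring carbon. Among the compounds with values here, two measured steps bear on this change. The step at the same place, a number 26 percentage points higher from compound 1 to compound 2 (beyond the scatter), was modest, and the step a little further along the chain, a number 11 percentage points lower from compound 2 to compound 3 (beyond the scatter), was modest as well. Both show that exchanging the group on this chain shifts the read-out by a modest amount, so replacing the group of compound 2 is expected to lower inhibition, with a step estimated at a number 19 percentage points lower from compound 2 to compound 4 (beyond the scatter). Compound 4 is therefore estimated at 80%, with a range from 60% to 95%.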

Compound 4, a percentage reported as inhibition, in the whole organism at one dose (the size of the read-out at that dose, not a potency): 44%
Beside the measured number, compound 4's estimate is 36 percentage points above it; measured number outside the range, below it.
By their numbers in this assay, from the lowest: compound 4; then compound 1; then compound 3; then compound 2.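

The exchange on this chain is not always modest: in this assay ethoxy brings a number 55 percentage points lower from compound 2 to compound 4 (beyond the scatter) and a number 44 percentage points lower from compound 3 to compound 4 (beyond the scatter) as large steps. Even against compound 1, previously the lowest, there is a number 29 percentage points lower from compound 1 to compound 4 (beyond the scatter) as a modest step, so compound 4 now stands lowest of the four. Size of the group alone does not order the series, since the ethoxy group is the smallest group here yet compound 1 and compound 2 differ widely too.

Going by these compounds, whether a propoxy group or an amine at this place would hold inhibition stays open. Nothing shown accounts for the size of these drops.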